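Chloro in Place of Hydrogen at the Assay Limit

The compounds below may be only part of what the source reports. "The series", "measured", "known", "first", "only" and "open" are said of these compounds alone.

Compound 1 `COc1cccc(-c2n[nH]cc2N2CCNCC2)c1`: in an assay on isolated protein for binding affinity to 5-hydroxytryptamine receptor 1E (Homo sapiens) (a higher number here means a weaker inhibitor, a lower number a stronger inhibitor), compound 1 gives > 10000 nM, a limit of the assay.
Compound 2 `c1ccc(-c2n[nH]cc2N2CCNCC2)cc1`: in this assay compound 2 gives > 10000 nM, also a limit of the assay.

Compound 2 thus stands only at a limit, as does compound 1, both sitting at the limit of > 10000 nM in this assay, at which 2 of the 2 values shown sit. The step that the two limits leave unreadable from compound 1 to compound 2 is therefore unreadable. Compound 3 `Clc1cccc(-c2n[nH]cc2N2CCNCC2)c1` differs from compound 2 by chloro in place of hydrogen on an aromatic carbon. Among the compounds with values here, no measured step bears on this change, so no direction beyond the scatter can be expected. Compound 3 is expected to give about 15000 nM, between 3000 nM and 80000 nM. This corresponds to an expected step that the limit leaves unreadable from compound 2 to compound 3.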

Compound 3, inhibition constant: > 10000 nM
Compound 3 ended at the assay's limit; the forecaster's own chance of this, stated with the estimate: 80%; the middle value does not contradict the limit.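

Compound 3, like compound 1 and compound 2, stands only at a limit of this assay, so no step among the three can be read: the limit of > 10000 nM in this assay, at which 3 of the 3 values shown sit.

The compounds shown leave open how far any of these aromatic substituents changes binding, since none gives a value beyond that limit.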